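This account rests on a few compounds, and the source may have more. Where it says the series, first, only, none or still open, it means among the compounds named here.

In an assay on isolated protein for inhibition of Amine oxidase [flavin-containing] B (Homo sapiens), read by fluorescence and Amplex Red, with stated times of 15 min and 20 min (a higher number here means a weaker inhibitor, a lower number a stronger inhibitor), compound 1 `Oc1ccc(O)c(/C=N/c2ccc(OCc3ccccc3)cc2)c1` gives 1230 nM. Compound 2 `Oc1ccccc1/C=N/c1ccc(OCc2ccccc2)cc1` gives 25100 nM, a change of a 20-fold higher number from compound 1 to compound 2 (1.31 log units; beyond the scatter). Compound 3 `Cc1ccc(/C=N/c2ccc(OCc3ccccc3)cc2)c(O)c1` gives 24400 nM, reached by a 20-fold higher number from compound 1 to compound 3 (1.30 log units; beyond the scatter); this is the second highest of the three numbers, the nearest being that of compound 2 and the furthest that of compound 1. Compound 4 `Cc1cccc(/C=N/c2ccc(OCc3ccccc3)cc2)c1O` has not yet been measured in this assay; it differs from compound 3 by 2-hydroxy-3-methylphenyl in place of 2-hydroxy-4-methylphenyl on a carbon with a double bond to nitrogen. The step that bears on this is a 1.0-fold lower number from compound 2 to compound 3 (0.01 log units; within the scatter), where a methyl entered without effect beyond the scatter; the large steps of a 20-fold higher number from compound 1 to compound 2 (1.31 log units; beyond the scatter) and a 20-fold higher number from compound 1 to compound 3 (1.30 log units; beyond the scatter) each involve a hydroxy and do not apply here. Compound 4 is therefore expected to show no step beyond the scatter, a 1.0-fold lower number from compound 3 to compound 4 (0.01 log units; within the scatter). Compound 4 is estimated at 24000 nM, within a range from 10000 nM to 55000 nM.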

Compound 4, half-maximal inhibitory concentration: 15500 nM
The estimate for compound 4 lay 1.5-fold (0.19 log units) above the measured number; the range from low to high includes it.
By their numbers in this assay, from the lowest: compound 1; then compounds 4, 3 and 2 (each within the scatter of the next).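

In this assay the swap of 2-hydroxy-4-methylphenyl for 2-hydroxy-3-methylphenyl gives a 1.6-fold lower number from compound 3 to compound 4 (0.20 log units; within the scatter) and the methyl added in this other arrangement gives a 1.6-fold lower number from compound 2 to compound 4 (0.21 log units; within the scatter) so neither placement of the methyl moves the number beyond the scatter. Even so, the 2-hydroxy-3-methylphenyl group remains well short of the 2,5-dihydroxyphenyl group, with a 13-fold higher number from compound 1 to compound 4 (1.10 log units; beyond the scatter) as the step between them. No available evidence bears on this result. As far as these compounds go, whether an amine or a carboxylic acid in place of this methyl would narrow that gap remains open.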